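The source may report more compounds than this note shows. Statements on the series, on what has been measured and on what is new or still open speak of the compounds shown alone.

Compound 1: `N=C(NCCCc1c[nH]cn1)NCCC(c1ccccc1)c1ccccn1` — 97.7 nM
Compound 2: `N=C(NCCCc1c[nH]cn1)NCCC(c1cccc(F)c1)c1ccccn1` — 158 nM
Compound 3: `N=C(NCCCc1c[nH]cn1)NCCC(c1ccccn1)c1ccccc1F` — 437 nM

Of the compounds shown here, three sharing one core have been measured in a functional assay on ileum for antagonist activity at histamine H1 receptor (Cavia porcellus); a higher number here means weaker binding, a lower number tighter binding. Compound 1 gives 97.7 nM, the lowest of the three numbers. Adding a single fluoro in place of hydrogen on an aromatic carbon to reach compound 2 gives a 1.6-fold higher number from compound 1 to compound 2 (0.21 log units; within the scatter), while the other placement of that fluoro in compound 3 gives a 4.5-fold higher number from compound 1 to compound 3 (0.65 log units; beyond the scatter). Between the two fluoro compounds there is a 2.8-fold higher number from compound 2 to compound 3 (0.44 log units; beyond the scatter).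

Compound 4, `N=C(NCCCc1c[nH]cn1)NCCC(c1cc(F)cc(F)c1)c1ccccn1`, has not yet been measured. It differs from compound 1 in one place: 3,5-difluorophenyl in place of phenyl on a saturated chain carbon bound to an aromatic carbon and a saturated chain carbon. Both measured fluoro steps bear on this change. The step with the 3-fluorophenyl compound 2 stayed within the scatter, and the step to compound 3 was modest. Within the data shown here, compound 4 carries two fluorines in the 3,5-difluorophenyl group, so a step somewhat larger than the one to compound 2 is expected, in the direction of a higher number, most likely beyond the scatter but still modest: a 2.3-fold higher number from compound 1 to compound 4 (0.35 log units; beyond the scatter). The estimate for compound 4 is therefore 220 nM, with a range from 100 nM to 500 nM.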

Compound 4, dissociation constant: 275 nM
The estimate for compound 4 lay 1.3-fold (0.10 log units) below the measured number; the measured number falls inside the stated range.
By their numbers in this assay, from the lowest: compounds 1, 2, 4 and 3 (each within the scatter of the next, the first and the last beyond it).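

In this assay the phenyl on the saturated chain carbon now carries two fluorines, and together they move the number beyond the scatter (a 2.8-fold higher number from compound 1 to compound 4 (0.45 log units; beyond the scatter)), although the second fluoro added on its own stays within it (a 1.7-fold higher number from compound 2 to compound 4 (0.24 log units; within the scatter)). The count of fluorines alone does not order these compounds: the 2-fluorophenyl group with one fluorine and the 3,5-difluorophenyl group with two stay within the scatter of each other (a 1.6-fold lower number from compound 3 to compound 4 (0.20 log units; within the scatter)). Fluoro in place of hydrogen on an aromatic carbon can now be compared on two cores, and the two steps do not differ beyond what repeated measurement allows: the same change on two cores in this assay, a 4.5-fold higher number (0.65 log units; beyond the scatter) from compound 1 to compound 3 and a 1.7-fold higher number (0.24 log units; within the scatter) from compound 2 to compound 4, 2.6-fold (0.41 log units) apart, within the scatter of two such steps.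

The compounds shown carry only hydrogen or fluoro on this phenyl, so what a chloro, a methyl or a methoxy group would do at the same place stays open. They also leave open whether any group on this saturated chain carbon can bring the number in this assay below that of compound 1 by more than the scatter.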